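A few compounds are considered here, and "the series" means these few. Any claim that something is new, unique, unknown or untested is made for them only; others in the source may bear on it.

Measured in a functional assay on HepG2 cells (Homo sapiens) for antiproliferative activity, read by MTT assay, with a stated time of 72 h; a lower number here means a stronger inhibitor, a higher number a weaker inhibitor:
Compound 1 `O=C1O/C(=C\Cn2cnc3ccn(C/C=C4\OC(=O)C(OCc5ccccc5)=C4OCc4ccccc4)c3c2=O)C(OCc2ccccc2)=C1OCc1ccccc1`: > 100000 nM
Compound 2 `O=C1O/C(=C\Cn2cnc3cc[nH]c3c2=O)C(OCc2ccccc2)=C1OCc1ccccc1`: > 100000 nM
Compound 3 `O=C1NC(O)(CCn2cnc3ccn(CCC4(O)NC(=O)C(OCc5ccccc5)=C4OCc4ccccc4)c3c2=O)C(OCc2ccccc2)=C1OCc1ccccc1`: > 100000 nM; 52000 nM (2 entries)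

Compound 2 has no exact number: its > 100000 nM is a limit of the assay. Compound 1 also stands at a limit, > 100000 nM. Together they make up most of the record, (the limit of > 100000 nM in this assay, at which 2 of the 3 values shown sit). Compound 3 alone has a number, and its record is split: the several entries of compound 3 in this assay, > 100000 nM; 52000 nM (2 entries).

Compound 4 `O=C1O/C(=C\Cn2cnc3c(Cl)c(F)nc(F)c32)C(OCc2ccccc2)=C1OCc1ccccc1` keeps the rest of compound 2 and changes one group, (a group of 12 heavy atoms (6 carbon, 3 nitrogen, 2 fluorine, 1 chlorine; one five-membered aromatic ring with 2 hetero atoms, one six-membered aromatic ring with 1 hetero atom) in place of a group of 10 heavy atoms (6 carbon, 3 nitrogen, 1 oxygen; one five-membered aromatic ring with 1 hetero atom, one six-membered aromatic ring with 2 hetero atoms), on a saturated chain carbon bound to a double-bonded chain carbon). For the measured compounds named here, no measured pair of compounds shows what a swap like this does, so its size cannot be read from the data. Compound 2 sits at a limit, so any measurable change would have to be towards stronger inhibition, and that is the direction expected here. The expected step is an at least 5.0-fold lower number from compound 2 to compound 4 (0.69 log units; beyond the scatter), and its size is uncertain. Compound 4 could still return only a limit. For compound 4 the estimated value is 20000 nM, with an expected range from 3000 nM to 100000 nM.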

Compound 4, half-maximal inhibitory concentration: > 100000 nM
Compound 4: a limit, no number (the forecaster's own chance of this, stated with the estimate: 35%); middle value at least 5.0-fold (0.69 log units) from the limit.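

For the compounds shown here, compound 2 and compound 4 both stand at a limit rather than a number, so no step between them can be read: the limit of > 100000 nM in this assay, at which 3 of the 4 values shown sit. The compounds shown leave open how strongly either compound inhibits in this assay, and whether swapping the group changes that at all.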